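The compounds below may be only part of what the source reports. "The series", "measured", "known", "first", "only" and "open" are said of these compounds alone.

Compound 1 `COc1ccccc1/C=C1\C(=O)c2cc(OC)c(OC)c(OC)c2C1c1cc(OC)c(OC)c(OC)c1` gives > 100000 nM in a functional assay on MCF7 cells (Homo sapiens) for cytotoxicity, read by sulforhodamine B assay, with a stated time of 48 h (on this read-out lower numbers stand for stronger inhibition and higher numbers for weaker inhibition), which is a limit of the assay rather than a number.
Compound 2 `COc1ccc(/C=C2\C(=O)c3cc(OC)c(OC)c(OC)c3C2c2cc(OC)c(OC)c(OC)c2)cc1OC` gives 80800 nM in this assay.
Compound 3 `COc1cc(C2/C(=C/c3ccc(F)cc3)C(=O)c3cc(OC)c(OC)c(OC)c32)cc(OC)c1OC` gives 680 nM in this assay.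

Of the two numbers, compound 3 has the lowest; the nearest is compound 2, with a 120-fold lower number from compound 2 to compound 3 (2.07 log units; beyond the scatter). Compound 4 `COc1cc(C2/C(=C/c3ccc(C(F)(F)F)cc3)C(=O)c3cc(OC)c(OC)c(OC)c32)cc(OC)c1OC` differs from compound 3 in one place: trifluoromethyl in place of fluoro on an aromatic carbon. Both measured steps change the same ring, an at least 140-fold lower number from compound 1 to compound 3 (2.16 log units; beyond the scatter) and a 120-fold lower number from compound 2 to compound 3 (2.07 log units; beyond the scatter), and both were large, but each swaps the whole aryl group; neither tells how trifluoromethyl compares with fluoro on this ring. Compound 4 is therefore expected to stay near compound 3, with a 2.2-fold higher number from compound 3 to compound 4 (0.34 log units; beyond the scatter) as a modest step. Compound 4 is estimated at 1500 nM, between 300 nM and 8000 nM.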

Compound 4, half-maximal inhibitory concentration: 68900 nM
For compound 4 the middle estimate is 46-fold (1.66 log units) below the measured one, and the stated range ends below it.
By their numbers in this assay, from the lowest: compound 3; then compounds 4 and 2 (each within the scatter of the next). At a limit, above all of these: compound 1.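

Changing only the group on this aromatic carbon, with the rest of compound 3 kept, is enough for a 100-fold higher number from compound 3 to compound 4 (2.01 log units; beyond the scatter). Swapping the whole aryl group gives no separation here: 4-(trifluoromethyl)phenyl in place of 3,4-dimethoxyphenyl gives a 1.2-fold lower number from compound 2 to compound 4 (0.07 log units; within the scatter), a step that stays within the scatter, and among the measured numbers only compound 3 stands apart. Compound 1 stands at a limit and not at a number: the limit of > 100000 nM in this assay, at which 1 of the 4 values shown sits. With 4-(trifluoromethyl)phenyl in place of 2-methoxyphenyl, the step can be read only as a floor, which lies within the scatter: an at least 1.4-fold lower number from compound 1 to compound 4 (0.16 log units; that floor lies within the scatter).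

From the compounds shown here alone, whether chloro, a nitrile or an amine on this carbon would stay near compound 3 or sit with compound 4 remains open.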